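The source may report more compounds than this note shows. Statements on the series, on what has been measured and on what is new or still open speak of the compounds shown alone.

Measured compounds in an assay for activation of Adrenergic receptor alpha-1 (Rattus norvegicus); a higher number here means that more compound is needed for the effect, a lower number that less compound is needed:
- compound 1, `c1ccc2c(c1)CCC2CCN1CCN(c2cccc3c2OCCO3)CC1`: 4.01 mg/kg
- compound 2, `c1ccc2c(c1)CCCCC2CCN1CCN(c2cccc3c2OCCO3)CC1`: a limit, > 2.5 mg/kg

Within the data shown here, compound 1 holds the only full number seen in this assay; the other entry is a limit. Compound 2 is recorded in this assay only as > 2.5 mg/kg, which is a limit of the assay and not a measured number (the limit of > 2.5 mg/kg in this assay, at which 1 of the 2 values shown sits). Compound 3, `Clc1cccc2c1CC2CCN1CCN(c2cccc3c2OCCO3)CC1`, remains to be measured in this assay. It differs from compound 1 by a group of 9 heavy atoms (8 carbon, 1 chlorine; one four-membered non-aromatic ring of carbon only, one six-membered aromatic ring of carbon only) in place of a group of 9 heavy atoms (9 carbon; one five-membered non-aromatic ring of carbon only, one six-membered aromatic ring of carbon only), on a saturated chain carbon, two bonds along the chain from an amine nitrogen in a ring. Among the measured compounds shown here, no pair of measured compounds shares this change, so no measured step shows its size or direction. The change keeps the overall shape of the group that hangs from the chain, so the step in this assay is expected to be modest, in either direction, and plausibly not beyond the usual scatter. Compound 3 is therefore expected to give about 4 mg/kg in this assay, with a range from 1.5 mg/kg to 12 mg/kg. The expected step is a 1.0-fold lower number from compound 1 to compound 3 (0.00 log units; within the scatter).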

Compound 3, dose for half-maximal effect: 20 mg/kg
Estimate against measurement, compound 3: 5.0-fold (0.70 log units) below; the measured number lies above the stated range.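

In this assay the group on the saturated chain carbon, two bonds along the chain from an amine nitrogen in a ring, proves not to be interchangeable: the swap gives a 5.0-fold higher number from compound 1 to compound 3 (0.70 log units; beyond the scatter), although the count of heavy atoms stays the same. The swap brings a four-membered ring in place of a five-membered one and a chlorine together, and no measurement shown accounts for the step. Compound 2 remains a limit of the assay and adds no number for this position: the limit of > 2.5 mg/kg in this assay, at which 1 of the 3 values shown sits.

As far as these compounds go, whether the ring size or the chlorine carries the step stays open. The four-membered ring group without chlorine, or the 2,3-dihydro-1H-inden-1-yl group carrying a chlorine, would separate the two parts of the change.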